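This account rests on a few compounds, and the source may have more. Where it says the series, first, only, none or still open, it means among the compounds named here.

Measured in a functional assay on KYSE-70 cells for antiproliferative activity against KYSE-70 cell line (Homo sapiens), read by MTT assay, with a stated time of 72 h; a higher number here means a weaker inhibitor, a lower number a stronger inhibitor:
- Compound 1 `O=C(Nc1cccc(F)c1)c1cc(=O)[nH]c2cc(Br)ccc12`: 8900 nM
- Compound 2 `CC(C)(C)c1ccc(-c2ccc3c(C(=O)Nc4cccc(F)c4)cc(=O)[nH]c3c2)cc1`: > 20000 nM, a limit of the assay
- Compound 3 `COc1ccc(-c2ccc3c(C(=O)Nc4cccc(F)c4)cc(=O)[nH]c3c2)cc1`: > 20000 nM, a limit of the assay

Compound 3 has no exact number, only the limit > 20000 nM. Compound 4 `Cc1ccc(-c2ccc3c(C(=O)Nc4cccc(F)c4)cc(=O)[nH]c3c2)cc1` carries methyl in place of methoxy on an aromatic carbon, para to a large group: methyl in place of methoxy on an aromatic carbon. Two steps show what 4-methoxyphenyl and 4-(tert-butyl)phenyl did in place of bromo: an at least 2.2-fold higher number from compound 1 to compound 3 (0.35 log units; beyond the scatter) and an at least 2.2-fold higher number from compound 1 to compound 2 (0.35 log units; beyond the scatter). The closest comparison, a swap at this same place, is unreadable: a step that the two limits leave unreadable from compound 2 to compound 3. Compound 2 and compound 3 both stop at the limit of > 20000 nM in this assay, at which 2 of the 3 values shown sit. Compound 4 keeps the large group, so it is expected to stay weak, with no clear step in this assay. The expected step is a step that the limit leaves unreadable from compound 3 to compound 4. Compound 4 is estimated at 22000 nM, within 11000 nM to 40000 nM.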

Compound 4, half-maximal inhibitory concentration: > 20000 nM
Compound 4: no number, only a limit; the forecaster's own chance of this, stated with the estimate: 70%; the middle value does not contradict the limit.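

Swapping bromo for 4-methylphenyl gives an at least 2.2-fold higher number from compound 1 to compound 4 (0.35 log units; beyond the scatter). Even a single carbon as the outer group on the added phenyl ring, in place of methoxy or tert-butyl, therefore does not restore a measurable value. The values of compound 2, compound 3 and compound 4 are all limits of the assay, and the steps among them cannot be read: the limit of > 20000 nM in this assay, at which 3 of the 4 values shown sit.

From the compounds shown here alone, whether the outer group matters at all stays open. So does whether a phenyl ring carrying an amine or a carboxylic acid, or an amine set directly in place of bromo, would give a measurable value.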